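Phenyl in place of pentyl at the ether chain

This account rests on a few compounds, and the source may have more. Where it says the series, first, only, none or still open, it means among the compounds named here.

Measured compounds in a functional assay on NCI-H1650 cells (Homo sapiens) for cytotoxicity, read by MTT assay, with a stated time of 48 h; on this read-out higher numbers stand for weaker inhibition and lower numbers for stronger inhibition:
compound 1 `CCCCOc1ccc2c(Cl)ccnc2c1` gives 2570 nM
compound 2 `CN(C)CCNc1ccnc2cc(OCc3ccccc3)ccc12` gives 1620 nM
compound 3 `CCCCCCOc1ccc2c(Cl)ccnc2c1` gives 2080 nM

Compound 3 stands among three numbers in this assay that all lie within the scatter of one another. Against compound 1 it shows a 1.2-fold lower number from compound 1 to compound 3 (0.09 log units; within the scatter), a chain extension that moved nothing beyond the scatter. Going by the values given here, compound 2 has no single-point step to compound 3; its number simply sits in the same band.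

Compound 4 `Clc1ccnc2cc(OCc3ccccc3)ccc12` is the next member. It differs from compound 3 by phenyl in place of pentyl on a saturated chain carbon bound to an oxygen on an aromatic ring. Among the compounds with values here, only one measured step bears on this position: the step from compound 1 to compound 3, a 1.2-fold lower number from compound 1 to compound 3 (0.09 log units; within the scatter), which altered the same chain and stayed within the scatter. Within the data shown here, no measured step swaps a chain for a ring at this place. Compound 2 carries the same benzyl ether as compound 4 while differing elsewhere on the core, and its value shows that such an ether member of the series lands within the scatter of compound 3.

On this basis the expected change in this assay from compound 3 to compound 4 is a 1.1-fold lower number from compound 3 to compound 4 (0.04 log units; within the scatter), nothing beyond the scatter. Compound 4 is therefore estimated at 1900 nM, within 900 nM to 4000 nM.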

Compound 4, half-maximal inhibitory concentration: 2720 nM
The estimate for compound 4 lay 1.4-fold (0.16 log units) below the measured number; measured number inside the range.
By their numbers in this assay, from the lowest: compounds 2, 3, 1 and 4 (each within the scatter of the next).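

In this assay, replacing the chain with a ring at this ether position gives no separation from the pentyl ether (step: a 1.3-fold higher number from compound 3 to compound 4 (0.12 log units; within the scatter)) or from the ether with the shorter chain (step: a 1.1-fold higher number from compound 1 to compound 4 (0.02 log units; within the scatter)), so all three ethers in this comparison lie within the scatter. Going by these compounds alone, compound 4 also gives the first matched reading at the other varied place, with the benzyl ether held constant: chloro in place of (2-(dimethylamino)ethyl)amino on an aromatic carbon also stays within the scatter (step: a 1.7-fold higher number from compound 2 to compound 4 (0.23 log units; within the scatter)). No outside evidence bears on this result.

The compounds shown leave open whether any ether group can move the number beyond the scatter in this assay, for instance a phenyl ring carrying a fluoro or methoxy group, or a chain ending in an amine or a carboxylic acid. Also open, as far as these compounds go, is whether the (2-(dimethylamino)ethyl)amino group behaves in the same way when paired with a butyl or hexyl ether instead of the benzyl ether.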